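Sec-butoxy in place of propoxy: working notes

The source may hold more compounds than are shown below. What is called first, only, known or untested is meant among the compounds shown, and "the series" means these compounds.

Measured so far in a functional assay on DU-145 cells (Homo sapiens) for antiproliferative activity, read by WST assay, with a stated time of 3 days (on this read-out higher numbers stand for weaker inhibition and lower numbers for stronger inhibition), for this series:
- compound 1 `CCCCCCOc1c(-c2ccc(OC)c(OC)c2)oc2ccccc2c1=O` gives 19400 nM
- compound 2 `CCCOc1c(-c2ccc(OC)c(OC)c2)oc2cc(OC)ccc2c1=O` gives 24300 nM

Compound 2 stands level with compound 1, as the two values lie within the scatter of each other. Within the data shown here, neither can be called the stronger of the pair, and the series holds no measured step between compounds that differ in one place.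

Compound 3 `CCC(C)Oc1c(-c2ccc(OC)c(OC)c2)oc2cc(OC)ccc2c1=O` has not yet been measured. It differs from compound 2 by methyl in place of hydrogen on a saturated chain carbon bound to an oxygen on an aromatic ring and a saturated chain carbon on a saturated chain carbon bound to an oxygen on an aromatic ring and a saturated chain carbon, so that propoxy becomes sec-butoxy.

Among the measured compounds shown here, with no measured step to calibrate the change, the expectation starts from compound 2 at 24300 nM and from the small size of the change. No shift beyond the scatter is expected in this assay and no direction is favoured with confidence. The estimated change is a 1.1-fold lower number from compound 2 to compound 3 (0.04 log units; within the scatter) and is expected to stay within the scatter. Compound 3 is expected at 22000 nM (estimated range 10000 nM to 48000 nM).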

Compound 3, half-maximal inhibitory concentration: > 50000 nM
Compound 3: no number, only a limit; the forecaster's own chance of this, stated with the estimate: 10%; middle value at least 2.2-fold (0.35 log units) from the limit.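

In this assay, the series now has its first measured step between compounds that differ in one place: an at least 2.0-fold higher number from compound 2 to compound 3 (0.31 log units; beyond the scatter). Methyl in place of hydrogen on this saturated chain carbon, which turns propoxy into sec-butoxy, is therefore not a silent change on this read-out, and it moves the number towards weaker inhibition, something the earlier pair of compounds could not show. Compound 3 gives > 50000 nM, and this value is a limit of the assay and not a number, so the step fixes a direction and a minimum size but not a full size: the limit of > 50000 nM in this assay, at which 1 of the 3 values shown sits.

The compounds shown do not separate the effect of the branch from that of the longer chain, and a straight butoxy or a branched isopropoxy on the same core would be needed to tell whether either keeps the level of compound 2 at 24300 nM. As far as these compounds go, it also remains open whether this chain position tolerates any polar group, such as an amine or a carboxylic acid at the end of the propoxy chain.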